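Aryl group on the ring nitrogen: chloro, bromo, iodo

The source may hold more compounds than are shown below. What is called first, only, known or untested is meant among the compounds shown, and "the series" means these compounds.

Measured so far, in a functional assay on HepG2 cells (Homo sapiens) for inhibition, read by MTT assay, with a stated time of 72 h; a lower number here means a stronger inhibitor, a higher number a weaker inhibitor:
compound 1 `CCc1cccc(-n2cc(COc3cccc(NC(=O)Nc4ccc(Cl)c(C(F)(F)F)c4)c3)nn2)c1`, 37900 nM
compound 2 `O=C(Nc1cccc(OCc2cn(-c3ccc(Cl)cc3)nn2)c1)Nc1ccc(Cl)c(C(F)(F)F)c1`, 2490 nM
compound 3 `O=C(Nc1cccc(OCc2cn(-c3ccc(Br)cc3)nn2)c1)Nc1ccc(Cl)c(C(F)(F)F)c1`, 2730 nM

Compound 1 gives the highest number of the three. The two steps away from it are both large and in the same direction: a 15-fold lower number from compound 1 to compound 2 (1.18 log units; beyond the scatter) and a 14-fold lower number from compound 1 to compound 3 (1.14 log units; beyond the scatter). Between the two halogens the numbers do not separate: a 1.1-fold higher number from compound 2 to compound 3 (0.04 log units; within the scatter).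

Compound 4 `O=C(Nc1cccc(OCc2cn(-c3ccc(I)cc3)nn2)c1)Nc1ccc(Cl)c(C(F)(F)F)c1` has not been measured. It differs from compound 1 as follows: 4-iodophenyl in place of 3-ethylphenyl on an aromatic nitrogen. The change is the same kind of move as from compound 1 to compound 2 and from compound 1 to compound 3, only with a heavier halogen at the same position of the entering group. Both of those steps bear directly on it, and both were large; the bromo-for-chloro step showed no change beyond the scatter, so no further shift from the halogen alone is indicated by the data in hand. A large step down in this assay is therefore expected, of about the size seen for the chloro and bromo compounds: a 14-fold lower number from compound 1 to compound 4 (1.15 log units; beyond the scatter). Compound 4 is estimated at 2700 nM, within the range 1200 nM to 6500 nM.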

Compound 4, half-maximal inhibitory concentration: 2690 nM
Compound 4: the middle estimate sits 1.0-fold (0.00 log units) above what was measured; low and high end bracket the measured number.
By their numbers in this assay, from the lowest: compounds 2, 4 and 3 (each within the scatter of the next); then compound 1.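

In this assay, the 4-iodophenyl group gives a large step (a 14-fold lower number from compound 1 to compound 4 (1.15 log units; beyond the scatter)), so the drop on leaving 3-ethylphenyl on the aromatic nitrogen now holds for three halogen-bearing aryl groups rather than two. Iodo in place of bromo (a 1.0-fold lower number from compound 3 to compound 4 (0.01 log units; within the scatter)) and iodo in place of chloro (a 1.1-fold higher number from compound 2 to compound 4 (0.03 log units; within the scatter)) both stay within the scatter, so compounds 2, 3 and 4 do not separate and, across these three compounds, exchanging the halogen on this aromatic carbon has no readable effect on the number. The data in hand offer no measurement that would account for either the large step or the flat halogen series.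

The change from 3-ethylphenyl to a 4-halophenyl group alters both the substituent and where it sits on the ring, so the compounds shown cannot tell which of the two carries the large step. A 4-ethylphenyl or 3-chlorophenyl group would separate these, while an unsubstituted phenyl, a 4-methoxyphenyl or a 4-aminophenyl group would show whether the flat result extends beyond the halogens.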